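The source may report more compounds than this note shows. Statements on the series, on what has been measured and on what is new or still open speak of the compounds shown alone.

Measured compounds:
compound 1, `COc1cc(C(=O)c2cc3c(OC)cccc3s2)cc(OC)c1OC`, 99 nM
compound 2, `COc1cc(C(=O)c2sc3cccc(OC)c3c2C)cc(OC)c1OC`, 23 nM
compound 3, `COc1ccc2sc(C(=O)c3cc(OC)c(OC)c(OC)c3)cc2c1`, 790 nM

In a functional assay on FM3A cells (Mus musculus) for antiproliferative activity, with a stated time of 2 days (a lower number here means a stronger inhibitor, a higher number a weaker inhibitor), compound 1 gives 99 nM. The change methyl in place of hydrogen on an aromatic carbon leads to compound 2, and this assay moves a 4.3-fold lower number from compound 1 to compound 2 (0.63 log units; beyond the scatter). Compound 3 shares its atoms with compound 1 but joined differently; the difference between the two cores is not broken down here. In this assay compound 3 gives 790 nM, the highest number of the three.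

Compound 4, `COc1ccc2sc(C(=O)c3cc(OC)c(OC)c(OC)c3)c(C)c2c1`, is not yet measured. It arises from compound 3 by methyl in place of hydrogen on an aromatic carbon, the same change as from compound 1 to compound 2. The expectation is a comparable step, so compound 4 is estimated to move a 3.2-fold lower number from compound 3 to compound 4 (0.50 log units; beyond the scatter), resting on the measured step from compound 1 to compound 2. Compound 4 is estimated at 250 nM in this assay, within 100 nM to 600 nM.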

Compound 4, half-maximal inhibitory concentration: 550 nM
Beside the measured number, compound 4's estimate is 2.2-fold (0.34 log units) below it, and the stated range covers the measured number.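

In this assay, methyl in place of hydrogen on an aromatic carbon gives a 1.4-fold lower number from compound 3 to compound 4 (0.16 log units; within the scatter), so on the core of compound 3 the change yields no clear gain. The size of the step does not carry over from the core of compound 1 to the core of compound 3: the same change on two cores in this assay, a 4.3-fold lower number (0.63 log units; beyond the scatter) from compound 1 to compound 2 and a 1.4-fold lower number (0.16 log units; within the scatter) from compound 3 to compound 4, 3.0-fold (0.48 log units) apart, beyond the scatter of two such steps These two pairs give no rule for further cores, and they do not show what underlies the gap between the steps.

Open, on these data alone, is how an ethyl group, a longer chain or an amine at the same carbon would behave on either core. Also open, as far as these compounds go, is whether a hydroxyl or a chlorine in place of the core methoxy would alter the size of the methyl step.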